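The source may report more compounds than this note shows. Statements on the series, on what has been measured and on what is new or still open speak of the compounds shown alone.

Compound 3 `CCCn1c(=O)[nH]c2nc(-c3ccc(S(=O)(=O)N4CCN(C(C)c5ccccc5)CC4)cc3)[nH]c2c1=O` gives 8.34 nM in an assay on CHO cells for displacement of a labelled ligand from adenosine receptor A2b (Homo sapiens), read by scintillation counting, with a stated time of 75 min, in the presence of a further agent that is not named here (a lower number here means a stronger inhibitor, a higher number a weaker inhibitor), the highest number among the three measured compounds. Compound 1 `CCCn1c(=O)[nH]c2nc(-c3ccc(S(=O)(=O)N4CCN(c5ccccc5Br)CC4)cc3)[nH]c2c1=O` gives 0.137 nM and compound 2 `CCCn1c(=O)[nH]c2nc(-c3ccc(S(=O)(=O)N4CCN(c5ccc(C)cc5)CC4)cc3)[nH]c2c1=O` gives 0.706 nM in this assay. The steps that lead to compound 3 are a 61-fold higher number from compound 1 to compound 3 (1.78 log units; beyond the scatter) and a 12-fold higher number from compound 2 to compound 3 (1.07 log units; beyond the scatter), and between the other two the step is a 5.2-fold higher number from compound 1 to compound 2 (0.71 log units; beyond the scatter). Compound 4 `CCCn1c(=O)[nH]c2nc(-c3ccc(S(=O)(=O)N4CCN(Cc5ccc(Br)c(F)c5)CC4)cc3)[nH]c2c1=O` differs from compound 3 in one place: 4-bromo-3-fluorobenzyl in place of 1-phenylethyl on an amine nitrogen in a ring. All three measured steps concern the group on this ring nitrogen, and both steps ending at compound 3 ran upward when 1-phenylethyl entered. Compound 4 moves away from that group, and the lowest number of the set belongs to compound 1, which carries a bromine. Among the compounds with values here, a lower number than that of compound 3 is therefore expected for compound 4, though a benzyl has no direct precedent here, so the estimated step is taken as moderate, a 4.2-fold lower number from compound 3 to compound 4 (0.62 log units; beyond the scatter). Compound 4 is estimated at 2 nM, within 0.5 nM to 8 nM.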

Compound 4, inhibition constant: 0.473 nM
Compound 4: middle estimate off by 4.2-fold (0.63 log units), on the high side; the whole stated range lies above it.
By their numbers in this assay, from the lowest: compound 1; then compounds 4 and 2 (each within the scatter of the next); then compound 3.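

In this assay the change on the amine nitrogen in the ring from 1-phenylethyl to 4-bromo-3-fluorobenzyl gives an 18-fold lower number from compound 3 to compound 4 (1.25 log units; beyond the scatter) and so shows that a group other than an aryl group on this nitrogen can reach a low number, which compound 3 alone had left in doubt. With a 1.5-fold lower number from compound 2 to compound 4 (0.17 log units; within the scatter) the 4-bromo-3-fluorobenzyl cannot be told apart from 4-methylphenyl, while a 3.5-fold higher number from compound 1 to compound 4 (0.54 log units; beyond the scatter) leaves 2-bromophenyl with the lower number. Nothing available here explains these steps.

The change from compound 3 to compound 4 alters the carbon chain and adds bromine and fluorine at once, so the compounds shown cannot assign the step to any one of these. An unsubstituted benzyl, a 4-bromobenzyl or a longer chain such as 2-phenylethyl would be needed to separate them.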